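A few compounds are considered here, and "the series" means these few. Any claim that something is new, unique, unknown or untested is made for them only; others in the source may bear on it.

Of the compounds shown here, three built on a shared core have been measured in a functional assay on HCT-116 cells (Homo sapiens) for cytotoxicity, read by MTT assay, with a stated time of 72 h; a higher number here means a weaker inhibitor, a lower number a stronger inhibitor. Compound 1 `NCCCNc1c(C(=O)NCc2ccc(F)cc2)nc(Br)c2cccnc12` gives only a limit of this assay, > 20000 nM, and no number. Compound 2 `N[C@H]1CC[C@H](Nc2c(C(=O)NCc3ccc(F)cc3)nc(N3CCCCC3)c3cccnc23)CC1` reads 8000 nM and compound 3 `COc1ccc(CNC(=O)c2nc(Br)c3cccnc3c2N[C@H]2CC[C@H](N)CC2)cc1` reads 3000 nM, but neither is a single-place change from compound 1.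

Compound 4 `NCCNc1c(C(=O)NCc2ccc(F)cc2)nc(Br)c2cccnc12` has not yet been measured. It differs from compound 1 in one place: amino in place of aminomethyl on a saturated chain carbon, two bonds along the chain from a nitrogen on an aromatic ring. This puts amino in place of aminomethyl on a saturated chain carbon, two bonds along the chain from a nitrogen on an aromatic ring, so that 3-aminopropyl becomes 2-aminoethyl.

Going by the values given here, no measured pair shows what this change does in this assay, and the reference point is a limit rather than a number. The expectation is therefore for no step beyond the scatter, in either direction, and the expected change is a number no higher from compound 1 to compound 4 (the limit leaves the size open). Compound 4 is expected to give about 20000 nM, with an estimated range of 9000 nM to 40000 nM.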

Compound 4, half-maximal inhibitory concentration: > 20000 nM
Compound 4 ended at the assay's limit; the forecaster's own chance of this, stated with the estimate: 60%; the middle value sits exactly at the limit.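

Compound 1 and compound 4 both end at a limit rather than a number, so no step can be read between them: the limit of > 20000 nM in this assay, at which 2 of the 4 values shown sit.

The compounds shown leave open what the change from 3-aminopropyl to 2-aminoethyl does where the values on both sides are numbers.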